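Amide substituent variation on the shared core: compound 4

The compounds below may be only part of what the source reports. "The series", "measured", "known", "first", "only" and "open" are said of these compounds alone.

Compound 3 `CCCCNC(=O)c1ccc2c(ccn2-c2ncc3c(n2)N(c2ccn(C)n2)C(CC)C(=O)N3C)c1` gives 37300 nM in a functional assay on A549 cells (Homo sapiens) for antiproliferative activity, read by CCK-8 assay, with a stated time of 72 h; on this read-out lower numbers stand for stronger inhibition of growth and higher numbers for weaker inhibition of growth. Compound 1 `CCC1C(=O)N(C)c2cnc(-n3ccc4cc(C(=O)NC)ccc43)nc2N1c1ccn(C)n1`, the methyl amide, gives 43100 nM, and the two sit within the scatter of each other; compound 2 `CCC1C(=O)N(C)c2cnc(-n3ccc4cc(F)ccc43)nc2N1c1ccn(C)n1`, with fluorine in place of the amide, gives "not active" (no number reported), reported without a number. Among the measured compounds shown here, the only step across the amide substituent, a 1.2-fold lower number from compound 1 to compound 3 (0.06 log units; within the scatter), stays within the scatter. Compound 4 `CCC1C(=O)N(C)c2cnc(-n3ccc4cc(C(=O)NCC(C)C)ccc43)nc2N1c1ccn(C)n1` differs from compound 3 by isopropyl in place of propyl on a saturated chain carbon bound to an amide-type nitrogen, a rearrangement of the same three carbons. For the measured compounds named here, with the one relevant step flat, no movement beyond the scatter is expected for compound 4, whose value is estimated at 38000 nM (range 16000 nM to 95000 nM). The expected step is a 1.0-fold higher number from compound 3 to compound 4 (0.01 log units; within the scatter) for compound 4.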

Compound 4, concentration for 50% growth inhibition: 19200 nM
Compound 4: middle estimate off by 2.0-fold (0.30 log units), on the high side; measured number inside the range.
By their numbers in this assay, from the lowest: compounds 4, 3 and 1 (each within the scatter of the next, the first and the last beyond it).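

Isopropyl in place of propyl, a rearrangement of the same carbons, gives (in this assay) a 1.9-fold lower number from compound 3 to compound 4 (0.29 log units; within the scatter) and leaves compound 4 level with compound 3. Set against the methyl amide, the same chain gives a 2.2-fold lower number from compound 1 to compound 4 (0.35 log units; beyond the scatter), the first step at this position to clear the scatter, though a modest one, and the step to compound 3 does not clear it. No measured evidence accounts for this separation.

Open, on these data alone, is whether a longer chain, a cyclopropyl group or a terminal amine on the amide nitrogen would move growth inhibition further. Also open, as far as these compounds go, is whether the amide hydrogen is needed.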